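The compounds below may be only part of what the source reports. "The series", "measured", "known", "first", "only" and "open" are said of these compounds alone.

Measured compounds in a functional assay on SMMC-7721 cells (Homo sapiens) for cytotoxicity, read by MTT assay, with a stated time of 72 h; on this read-out lower numbers stand for stronger inhibition and higher numbers for weaker inhibition:
- compound 1, `NC(=O)N1CCN(C(=S)SCc2cn(Cc3ccc(F)cc3)nn2)CC1`, gives > 128000 nM, a limit of the assay rather than a number.
- compound 2, `CC(C)NC(=O)N1CCN(C(=S)SCc2cn(Cc3ccc(F)cc3)nn2)CC1`, gives 5970 nM.

Compound 2 thus holds the only number shown in this assay; the other value shown sits at the limit, (the limit of > 128000 nM in this assay, at which 1 of the 2 values shown sits). Within the data shown here, the one measured step, an at least 21-fold lower number from compound 1 to compound 2 (1.33 log units; beyond the scatter), is large and comes from placing isopropyl on a nitrogen that carried hydrogen in compound 1.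

Compound 3, `CCN(C)C(=O)N1CCN(C(=S)SCc2cn(Cc3ccc(F)cc3)nn2)CC1`, differs from compound 2 by ethyl(methyl)amino in place of isopropylamino on a carbonyl carbon. This change touches the same urea nitrogen as the measured step, so that step is the only one that bears on it. Compound 3 keeps the same atoms but arranges them as ethyl(methyl)amino, with no hydrogen on that nitrogen. The measured step does not separate the effect of carbon substitution from the loss of the hydrogen, so the direction is uncertain; a step of a 1.3-fold higher number from compound 2 to compound 3 (0.13 log units; within the scatter) is expected, within or near the scatter. Compound 3 is therefore estimated at 8000 nM, between 2500 nM and 30000 nM.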

Compound 3, half-maximal inhibitory concentration: 23700 nM
Beside the measured number, compound 3's estimate is 3.0-fold (0.47 log units) below it, and the stated range covers the measured number.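

In this assay, rearranging the same atoms on the carbonyl carbon gives a 4.0-fold higher number from compound 2 to compound 3 (0.60 log units; beyond the scatter), so this place responds to how the substituent is built and not only to which atoms it holds. The hydrogen-bond donor count is the one computed difference between the two groups, as isopropylamino carries one and ethyl(methyl)amino carries none. Ethyl(methyl)amino still retains a gain over amino, with an at least 5.4-fold lower number from compound 1 to compound 3 (0.73 log units; beyond the scatter), but that step gives only a bound and not a full size, since the value of compound 1 is a limit of the assay: the limit of > 128000 nM in this assay, at which 1 of the 3 values shown sits.

The compounds shown still do not separate the loss of the hydrogen on the nitrogen from the rearrangement of the carbons, as isopropylamino and ethyl(methyl)amino differ in both at once. Going by these compounds, it remains open whether ethylamino, which keeps that hydrogen, or diethylamino, which lacks it and carries a longer chain, would fall nearer to compound 2 or to compound 3 on the same carbonyl carbon.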